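The source may report more compounds than this note shows. Statements on the series, on what has been measured and on what is new or still open speak of the compounds shown alone.

Compound 1 `O=C(Nc1ccnc(C(F)(F)F)c1)Nc1ccc(F)c(C(F)(F)F)c1` is one of two ureas measured in an ADME assay on microsomes from liver (Homo sapiens) for metabolic stability, using NADPH, with a stated time of 60 min; on this read-out higher numbers stand for fast clearance and lower numbers for slow clearance. In this assay compound 1 gives < 7 uL/min, which is a limit of the assay rather than a number. Among the measured compounds shown here, compound 2 `O=C(Nc1cccnc1)Nc1ccc(F)c(C(F)(F)F)c1` gives 13 uL/min in this assay, and this is the only actual number in the set. The other result, that of compound 1, is the limit of < 7 uL/min in this assay, at which 1 of the 2 values shown sits. So compound 2 stands alone among the numbers shown, with nothing to rank it against. Compound 3 `O=C(Nc1ccncc1)Nc1ccc(F)c(C(F)(F)F)c1` is built from the same atoms as compound 2, joined differently: pyridin-4-yl in place of pyridin-3-yl on an amide-type nitrogen. For the measured compounds named here, no measured pair in the set differs in a single place, so there is no measured step to lean on. The expectation is a change no larger than the usual scatter, in no particular direction, so the step is estimated as no change at the digits printed from compound 2 to compound 3 (within the scatter). Compound 3 is therefore expected to give about 13 uL/min in this assay, within a range from 6 uL/min to 28 uL/min.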

Compound 3, intrinsic clearance in a liver preparation (reported as CLH), per the amount of preparation that the assay uses in the Homo sapiens assay: 12 uL/min
For compound 3 the middle estimate is 1.1-fold (0.03 log units) above the measured one; the measured number falls inside the stated range.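

Among the compounds shown here, in the Homo sapiens assay pyridin-4-yl in place of pyridin-3-yl on the amide-type nitrogen gives the first measured step at this place, a 1.1-fold lower number from compound 2 to compound 3 (0.03 log units; within the scatter), so the two attachments cannot be told apart on this read-out. In a physicochemical assay for lipophilicity, read by HPLC, measured as octanol-water partition, at pH 7.2 (a higher number here means a more lipophilic compound, a lower number a more polar compound), compound 2 gives 3 and compound 3 gives 3.2, and these two values also lie within the scatter of each other. In the Homo sapiens assay hydrogen in place of trifluoromethyl on an aromatic carbon gives an at least 1.7-fold higher number from compound 1 to compound 3 (0.23 log units; that floor lies within the scatter), but this is only a floor, as the starting value is a limit of the assay and not a number: the limit of < 7 uL/min in the Homo sapiens assay, at which 1 of the 3 values shown sits.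

Going by these compounds, the true size of that step therefore stays open. Also open, on these data alone, is whether an amine or a methoxy group on that same aromatic carbon would give a value apart from these.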